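A Fluorine on the Benzyl Ether of Compound 1

This account rests on a few compounds, and the source may have more. Where it says the series, first, only, none or still open, it means among the compounds named here.

Among the compounds with values here, compound 1 `FC(F)(F)c1ccc(CN2CCN(Cc3cc(-c4ccc(OCc5ccccc5)cc4)on3)CC2)cc1` carries a benzyloxy group on the shared core, and in a functional assay on Mahlavu cells (Homo sapiens) for antiproliferative activity, read by sulforhodamine B assay, with a stated time of 72 h (a higher number here means a weaker inhibitor, a lower number a stronger inhibitor), compound 1 gives 11700 nM, the highest of the three numbers measured so far. Within the data shown here, two neighbours alter only that benzyl ring. Compound 2 `Cc1cc(C)cc(COc2ccc(-c3cc(CN4CCN(Cc5ccc(C(F)(F)F)cc5)CC4)no3)cc2)c1` gives 6000 nM, and the change brings a 2.0-fold lower number from compound 1 to compound 2 (0.29 log units; within the scatter). Compound 3 `FC(F)(F)c1ccc(CN2CCN(Cc3cc(-c4ccc(OCc5ccc(Cl)cc5)cc4)on3)CC2)cc1` gives 3700 nM, and here the change brings a 3.2-fold lower number from compound 1 to compound 3 (0.50 log units; beyond the scatter). Between the two substituted analogues there is a 1.6-fold lower number from compound 2 to compound 3 (0.21 log units; within the scatter).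

Compound 4 `Fc1cccc(COc2ccc(-c3cc(CN4CCN(Cc5ccc(C(F)(F)F)cc5)CC4)no3)cc2)c1` is the next member of this set: fluoro in place of hydrogen on an aromatic carbon, so that the benzyloxy of compound 1 becomes (3-fluorobenzyl)oxy. The measured steps that bear on this are the two substitutions on the same ring: chloro gave a 3.2-fold lower number from compound 1 to compound 3 (0.50 log units; beyond the scatter), beyond the scatter, whereas 3,5-dimethylphenyl gave a 2.0-fold lower number from compound 1 to compound 2 (0.29 log units; within the scatter), within it. On the strength of these two steps, a lowering of the number for compound 4 is expected, of a size that may not clear the scatter, and the estimated step is a 1.7-fold lower number from compound 1 to compound 4 (0.22 log units; within the scatter). Compound 4 is therefore estimated at 7000 nM, within a range from 3500 nM to 14000 nM.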

Compound 4, half-maximal inhibitory concentration: 2900 nM
The estimate for compound 4 lay 2.4-fold (0.38 log units) above the measured number, outside the stated range (below it).
By their numbers in this assay, from the lowest: compounds 4, 3, 2 and 1 (each within the scatter of the next, the first and the last beyond it).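

In this assay, the entry of fluoro on an aromatic carbon of the benzyl ring, meta to a large group, gives a 4.0-fold lower number from compound 1 to compound 4 (0.61 log units; beyond the scatter), so one added heavy atom at this place is enough to clear the scatter, which the two methyl groups of compound 2 did not do. The comparison with the other substituted analogues separates them unequally: a 1.3-fold lower number from compound 3 to compound 4 (0.11 log units; within the scatter) leaves 3-fluorophenyl and 4-chlorophenyl indistinguishable in this assay, whereas a 2.1-fold lower number from compound 2 to compound 4 (0.32 log units; beyond the scatter) sets 3-fluorophenyl apart from 3,5-dimethylphenyl, a separation that compound 3 did not reach against compound 2. Nothing available accounts for the size of the fluoro step.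

Compound 3 and compound 4 differ in both the halogen and its place on the ring, so the compounds shown cannot say whether either one alone governs the number. On these data alone, it also remains open how this ring would respond to a methoxy group, a nitrile or an amine in the place of fluoro, and whether any such group would take the number beyond the scatter of compound 4.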